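From 2-chlorophenyl to 4-fluorophenyl on the shared core

This account rests on a few compounds, and the source may have more. Where it says the series, first, only, none or still open, it means among the compounds named here.

In a functional assay on HepG2 cells (Homo sapiens) for inhibition, read by MTT assay, with a stated time of 72 h (a lower number here means a stronger inhibitor, a higher number a weaker inhibitor), compound 1 `Cc1ccc(-c2cc(C(=O)N3CCC4(CC3)CC(=O)c3nn(C(C)(C)C)cc3O4)c3ccccc3n2)cc1` gives 1440 nM. Compound 2 `Cc1ccccc1-c1cc(C(=O)N2CCC3(CC2)CC(=O)c2nn(C(C)(C)C)cc2O3)c2ccccc2n1` gives > 10000 nM, which is a limit. Compound 3 `CC(C)(C)n1cc2c(n1)C(=O)CC1(CCN(C(=O)c3cc(-c4ccccc4Cl)nc4ccccc34)CC1)O2` gives > 10000 nM, also a limit. Compound 3 thus stands at the limit of > 10000 nM in this assay, at which 2 of the 3 values shown sit.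

Compound 4 `CC(C)(C)n1cc2c(n1)C(=O)CC1(CCN(C(=O)c3cc(-c4ccc(F)cc4)nc4ccccc34)CC1)O2` carries 4-fluorophenyl in place of 2-chlorophenyl on an aromatic carbon, next to the ring nitrogen: 4-fluorophenyl in place of 2-chlorophenyl on an aromatic carbon. Going by the values given here, two measured steps bear on this: an at least 6.9-fold higher number from compound 1 to compound 2 (0.84 log units; beyond the scatter) and an at least 6.9-fold higher number from compound 1 to compound 3 (0.84 log units; beyond the scatter), both beyond the scatter. Among the compounds with values here, the 4-fluorophenyl group resembles the 4-methylphenyl of compound 1 at 1440 nM, the only number in the set. A move to a lower number is therefore expected, estimated as an at least 4.0-fold lower number from compound 3 to compound 4 (0.60 log units; beyond the scatter). The expected value for compound 4 is 2500 nM, with an estimated range from 800 nM to 9000 nM.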

Compound 4, half-maximal inhibitory concentration: 2930 nM
Beside the measured number, compound 4's estimate is 1.2-fold (0.07 log units) below it; the range from low to high includes it.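

In this assay, this position, on an aromatic carbon next to the ring nitrogen, gives a second measured number with a 4-substituted phenyl group, through an at least 3.4-fold lower number from compound 3 to compound 4 (0.53 log units; beyond the scatter) and an at least 3.4-fold lower number from compound 2 to compound 4 (0.53 log units; beyond the scatter). Among the 4-substituted pair, fluoro in place of methyl gives a 2.0-fold higher number from compound 1 to compound 4 (0.31 log units; beyond the scatter), so the group at that ring position also moves the number. All four compounds fit this split, with compound 1 and compound 4 giving numbers and compound 2 and compound 3 giving limits.

The step between the two limits cannot be read. On these data alone, how an amine or a carboxylic acid on this phenyl ring would read stays open.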